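The compounds below may be only part of what the source reports. "The series", "measured", "known", "first", "only" and "open" are said of these compounds alone.

Measured so far:
Compound 1 `CC1(C)CCC(C)(C)c2c1cc(O)c(C(=O)c1ccc3cc(C(=O)O)ccc3c1)c2F`: in an assay on isolated protein with retinoic acid receptor beta (Homo sapiens) as the target (on this read-out higher numbers stand for larger maximal responses and lower numbers for smaller maximal responses), compound 1 gives 87%.
Compound 2 `COc1c(C(=O)c2ccc3cc(C(=O)O)ccc3c2)ccc2c1C(C)(C)CCC2(C)C`: in this assay compound 2 gives 0%.

Compound 1 stands highest of these two numbers; compound 2 is the nearest, and its number lies a long way lower, beyond the usual scatter of this kind of measurement. Compound 3 `CC1(C)CCC(C)(C)c2cc(C(=O)c3ccc4cc(C(=O)O)ccc4c3)c(O)cc21` has not yet been measured in this assay. Compared with compound 1 it differs in one place: hydrogen in place of fluoro on an aromatic carbon. For the measured compounds named here, nothing among the measured compounds shows what this exchange does, since compounds 1 and 2 differ in several places at once. The expected step is therefore uncertain: a small loss is thought most likely, though a change within the scatter cannot be ruled out, and the estimate amounts to a number 12 percentage points lower from compound 1 to compound 3 (beyond the scatter). For compound 3 the estimated value in this assay is 75%, with a range from 40% to 100%.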

Compound 3, largest response reached (reported as maximum), in percent of the reference or control that the assay uses: 76%
Compound 3: middle estimate off by 1 percentage points, on the low side, within the range that was stated.
By their numbers in this assay, from the lowest: compound 2; then compound 3; then compound 1.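

The fluoro on this aromatic carbon turns out not to be essential for a large maximal response: in this assay, exchanging it for hydrogen gives a number 11 percentage points lower from compound 1 to compound 3 (beyond the scatter), and compound 3 still reaches 76%. The loss is modest but lies beyond the scatter, so this single atom does make a measurable difference, something the earlier pair could not show because compounds 1 and 2 differ in several places at once. Nothing at hand explains why the fluoro and hydrogen versions differ.

From the compounds shown here alone, whether a larger group at this carbon, such as chloro or methyl, would give a response nearer that of compound 1 or compound 3 remains open. The steps to compound 2 cannot be read, so what lies behind its far lower number also stays unresolved.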